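This account rests on a few compounds, and the source may have more. Where it says the series, first, only, none or still open, it means among the compounds named here.

Measured so far:
- compound 1 `COc1cc(-c2cc(/C=C/C(=O)c3ccc(N)cc3)[nH]n2)cc(OC)c1OC`: 103%
- compound 2 `COc1ccc(C(=O)/C=C/c2cc(-c3cc(OC)c(OC)c(OC)c3)n[nH]2)cc1OC`: 101%

In a functional assay on NCI-H322M cells (Homo sapiens) for cytotoxicity, read by sulforhodamine B assay, with a stated time of 48 h, tested at 0.1 uM (on this read-out lower numbers stand for a stronger effect and higher numbers for a weaker effect at the one concentration tested), compound 1 gives 103%, and in this assay compound 2 gives 101%. Compound 2 holds the lowest of the two numbers, but its nearest neighbour, compound 1, sits only a number 2 percentage points lower from compound 1 to compound 2 (within the scatter), so the two read-outs are indistinguishable and both lie near the untreated level at the single concentration tested.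

Compound 3 `COc1cc(C(=O)/C=C/c2cc(-c3cc(OC)c(OC)c(OC)c3)n[nH]2)cc(OC)c1OC` is the next member of the series. Relative to compound 2 the change is methoxy in place of hydrogen on an aromatic carbon.

Among the measured compounds shown here, no measured step involves a methoxy entering in place of hydrogen, so nothing on record bears directly on this change. For the measured compounds named here, the only step at hand, a number 2 percentage points lower from compound 1 to compound 2 (within the scatter), swapped the whole group on the carbonyl carbon and stayed within the scatter. Given that both measured compounds show essentially no effect in this assay, the expectation for compound 3 is no step beyond the scatter, a number 1 percentage points lower from compound 2 to compound 3 (within the scatter). Compound 3 is therefore estimated at 100%, with a range from 86% to 112%.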

Compound 3, a percentage reported as activity, at one concentration (the size of the read-out at that concentration, not a potency): 97%
For compound 3 the middle estimate is 3 percentage points above the measured one; the measured number falls inside the stated range.
By their numbers in this assay, from the lowest: compounds 3, 2 and 1 (each within the scatter of the next).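

In this assay, the methoxy placed on this aromatic carbon, ortho to a methoxy group and meta to a large group, gives a number 4 percentage points lower from compound 2 to compound 3 (within the scatter), so the read-out of compound 3 cannot be separated from that of compound 2. Among the compounds shown here, this is the first reading for a methoxy in place of hydrogen, and it shows that this position accepts the added group with no effect beyond the scatter at the single concentration tested, as was also the case for the exchange of the whole group on the carbonyl carbon. No supporting data bear on the reason for this result.

All three compounds lie within the scatter of one another near the untreated level, so the compounds shown leave open whether this position influences cytotoxicity at all or whether any influence only appears at a higher concentration. Also open, going by these compounds, is whether a hydroxyl, an ethoxy or an amine in place of this methoxy would give a number beyond the scatter.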